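The source may hold more compounds than are shown below. What is called first, only, known or untested is meant among the compounds shown, and "the series" means these compounds.

Compound 1 `Cc1n[nH]c2ccc(-c3nc4cnc(N5CCN(C)CC5)cn4c3Nc3cccc(F)c3)cc12` gives 5.41% in a functional assay on CWR22R cells (Homo sapiens) for inhibition, with a stated time of 120 h, tested at 10 uM; a lower number here means less inhibition, a higher number more inhibition at the concentration tested (going by the name of the read-out). Compound 2 `Cc1n[nH]c2ccc(-c3nc4cnc(N5CCN(C)CC5)cn4c3Nc3ccccc3)cc12` gives "not determined" (no result reported) in this assay. Compound 3 `Cc1n[nH]c2ccc(-c3nc4cnc(N5CCN(C)CC5)cn4c3Nc3ccc(F)c(Cl)c3)cc12` gives 0.82% in this assay.

Going by the values given here, compound 2 therefore stands without a number in this assay; the two measured compounds around it both show small inhibition, and the only measured step, a number 4.6 percentage points lower from compound 1 to compound 3 (within the scatter), lies within the scatter. Compound 4 `Cc1n[nH]c2ccc(-c3nc4cnc(N5CCN(C)CC5)cn4c3Nc3cc(Cl)ccc3Cl)cc12` differs from compound 2 by 2,5-dichlorophenyl in place of phenyl on a nitrogen on an aromatic ring. Among the compounds with values here, no measured step covers this particular exchange, and the one step that exists, also a change of the ring on that nitrogen, gave no shift beyond the scatter. Compound 4 is thus expected to show a low inhibition in this assay, estimated at 4% (range -8% to 16%).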

Compound 4, a percentage reported as inhibition, at one concentration (the size of the read-out at that concentration, not a potency): 3.8%
Compound 4: the middle estimate sits 0.2 percentage points above what was measured; low and high end bracket the measured number.
By their numbers in this assay, from the lowest: compounds 3, 4 and 1 (each within the scatter of the next).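

With 2,5-dichlorophenyl on this nitrogen, three differently halogenated phenyl rings have now been compared in this assay, and none separates from the others: the data give a number 3 percentage points higher from compound 3 to compound 4 (within the scatter), and a number 1.6 percentage points lower from compound 1 to compound 4 (within the scatter). Swapping the number or kind of halogens on this ring therefore produced no readable shift among these compounds. Nothing on hand accounts for the uniformly small inhibition.

Left open is whether a ring bearing an amine or a carboxylic acid on this nitrogen would reach a higher inhibition. As far as these compounds go, it also remains open whether the unsubstituted anilino compound 2, which stands without a number, sits with these halogenated compounds.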